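A few compounds are considered here, and "the series" means these few. Any claim that something is new, unique, unknown or untested is made for them only; others in the source may bear on it.

Working notes on the series. In an assay on CHO cells with Alpha-2B adrenergic receptor (Homo sapiens) as the target (a higher number here means a larger maximal response, a lower number a smaller maximal response), compound 3 `CC(Oc1ccccc1Br)C1=NCCN1` gives 0.4, the lowest of the three numbers in hand. Compound 1 `CCOc1ccccc1OC(C)C1=NCCN1` gives 0.5 and compound 2 `CC(Oc1ccccc1OC1CC1)C1=NCCN1` gives 0.6. The steps to compound 3 are a number 0.10 lower from compound 1 to compound 3 (within the scatter) and a number 0.20 lower from compound 2 to compound 3 (beyond the scatter); between the two ethers the step is a number 0.10 higher from compound 1 to compound 2 (within the scatter).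

Compound 4 `CC(Oc1ccccc1S(C)(=O)=O)C1=NCCN1` differs from compound 3 by methylsulfonyl in place of bromo on an aromatic carbon. Both measured steps ending at compound 3 swap the group on this aromatic carbon for bromo, and they were small: one within the scatter, one modest and beyond it. Among the measured compounds shown here, no measured step introduces a methylsulfonyl anywhere, so the direction for compound 4 rests only on that pattern of small movement at this position. The expectation is therefore a small step, if any, from compound 3 to compound 4, a number 0.10 higher from compound 3 to compound 4 (within the scatter), most likely within the scatter. Compound 4 is estimated at 0.5, with a range from 0.3 to 0.7.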

Compound 4, intrinsic activity: the largest response reached, as a fraction of the reference agonist's: 0.45
Estimate against measurement, compound 4: 0.050 above, and the stated range covers the measured number.
By their numbers in this assay, from the lowest: compounds 3, 4, 1 and 2 (each within the scatter of the next, the first and the last beyond it).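

In this assay, the position tolerates a much larger replacement than earlier steps had tested: methylsulfonyl, with 4 heavy atoms and 2 hydrogen-bond acceptors, replaces bromo, with 1 heavy atom and none, for a number 0.050 higher from compound 3 to compound 4 (within the scatter), and replacing ethoxy gives a number 0.050 lower from compound 1 to compound 4 (within the scatter). Cyclopropyloxy is the exception among the groups at this aromatic carbon, since replacing it with methylsulfonyl gives a number 0.15 lower from compound 2 to compound 4 (beyond the scatter), in the same direction as a number 0.20 lower from compound 2 to compound 3 (beyond the scatter). Nothing available explains this tolerance at the position.

As far as these compounds go, the series covers only bromo, ethoxy, cyclopropyloxy and methylsulfonyl at this carbon, so it remains open whether an amine or a carboxylic acid would stay close to these values. From the compounds shown here alone, it also remains open whether a longer alkoxy chain would follow compound 2 rather than compound 1.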